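Carbonyl substituent variation in a chromene series: NF-kappa-B inhibition

The source may hold more compounds than are shown below. What is called first, only, known or untested is meant among the compounds shown, and "the series" means these compounds.

Measured so far:
compound 1, `COc1ccc2c(c1)OC(c1cc(OC)c(OC)c(OC)c1)C(C=O)=C2`, 13500 nM
compound 2, `COC(=O)C1=Cc2ccc(OC)cc2OC1c1cc(OC)c(OC)c(OC)c1`, 13800 nM
compound 3, `COc1ccc2c(c1)OC(c1cc(OC)c(OC)c(OC)c1)C(C(=O)OC(C)(C)C)=C2`, 14100 nM

Three compounds share one core and differ only in what sits on the carbonyl carbon. In a functional assay for inhibition of nuclear factor NF-kappa-B complex (Homo sapiens) (on this read-out lower numbers stand for stronger inhibition and higher numbers for weaker inhibition), compound 1 gives 13500 nM, compound 2 gives 13800 nM and compound 3 gives 14100 nM. Compound 2 sits second highest of the three numbers, but every gap is within the scatter: a 1.0-fold higher number from compound 1 to compound 2 (0.01 log units; within the scatter), a 1.0-fold higher number from compound 2 to compound 3 (0.01 log units; within the scatter) and a 1.0-fold higher number from compound 1 to compound 3 (0.02 log units; within the scatter). Going by the values given here, nothing among the measured steps separates hydrogen, methoxy or tert-butoxy on that carbonyl carbon.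

The next compound is compound 4, `COc1ccc2c(c1)OC(c1cc(OC)c(OC)c(OC)c1)C(C(N)=O)=C2`. Relative to compound 2 the change is amino in place of methoxy on a carbonyl carbon. The three measured steps bear on it directly, since each also swaps the group on the same carbonyl carbon, and all three were flat. The expectation for compound 4 is therefore no step beyond the scatter in this assay, in either direction, so that no change at the digits printed from compound 2 to compound 4 (within the scatter) is expected. Compound 4 is estimated at 13800 nM, with a range from 5500 nM to 35000 nM.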

Compound 4, half-maximal inhibitory concentration: > 50000 nM
Compound 4 ended at the assay's limit; the forecaster's own chance of this, stated with the estimate: 10%; middle value at least 3.6-fold (0.55 log units) away from the limit.
By their numbers in this assay, from the lowest: compounds 1, 2 and 3 (each within the scatter of the next). At a limit, above all of these: compound 4.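

In this assay compound 4 gives > 50000 nM, which is a limit of the assay and not a number: the limit of > 50000 nM in this assay, at which 1 of the 4 values shown sits.

The group on this carbonyl carbon is therefore not indifferent, since amino gives an at least 3.6-fold higher number from compound 2 to compound 4 (0.55 log units; beyond the scatter), along with an at least 3.5-fold higher number from compound 3 to compound 4 (0.54 log units; beyond the scatter) and an at least 3.7-fold higher number from compound 1 to compound 4 (0.56 log units; beyond the scatter). The flat response seen so far thus holds for hydrogen, methoxy and tert-butoxy only and does not extend to amino, the change that brings in a hydrogen-bond donor where methoxy has none.

From the compounds shown here alone, the true size of these steps remains open, as does whether they go with the amino hydrogens or with nitrogen on the carbonyl carbon as such. Dimethylamino or methylamino at this place would bear on that question, and a carboxylic acid would show how far the flat response extends among other oxygen groups.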